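Swapping pyridin-2-yl for phenyl on compound 2

This account rests on a few compounds, and the source may have more. Where it says the series, first, only, none or still open, it means among the compounds named here.

Measured so far in an ADME assay on the whole organism (Mus musculus, strain CD-1) for metabolic stability, read by LC-MS, with a stated time of 4 h, at a dose of 10 mg/kg by the intraperitoneal route; a higher number here means that the compound lasts longer, a lower number that the compound disappears faster
- Compound 1 `C[C@@H](Sc1nc2c(cnn2C)c(=O)n1-c1ccccc1)c1ccccc1` gives 0.5 h
- Compound 2 `CC(Sc1nc2c(cnn2C)c(=O)n1-c1ccccc1)c1ccccn1` gives 1.2 h
- Compound 3 `CC(Sc1nc2nn(C3COC3)cc2c(=O)n1-c1ccccc1)c1ccccn1` gives 0.6 h

Compound 2 has the largest number of the three, but its lead is not clear on every side. Compound 2 at 1.2 h and compound 3 at 0.6 h lie within the usual scatter of each other. Only the gap to compound 1 goes beyond that scatter.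

The next compound to consider is compound 4 `CC(Sc1nc2c(cnn2C)c(=O)n1-c1ccccc1)c1ccccc1`. It carries phenyl in place of pyridin-2-yl on a saturated chain carbon bound to a saturated chain carbon and a sulfur.

Among the measured compounds shown here, one measured step bears on this change, and it runs the opposite way, from phenyl to pyridin-2-yl. That step is a 2.4-fold higher number from compound 1 to compound 2 (0.38 log units; beyond the scatter), a modest move just beyond the scatter. Reversing it suggests a drop of similar size in this assay, although a single step is thin evidence. The expected change is a 2.4-fold lower number from compound 2 to compound 4 (0.38 log units; beyond the scatter). The estimated half-life for compound 4 is 0.5 h, with an expected range from 0.3 h to 0.9 h.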

Compound 4, half-life: 1.8 h
Compound 4: the middle estimate sits 3.6-fold (0.56 log units) below what was measured; measured number outside the range, above it.
By their numbers in this assay, from the lowest: compounds 1, 3, 2 and 4 (each within the scatter of the next, the first and the last beyond it).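

In this assay the swap to phenyl, read between two compounds both drawn without a configuration, gives a 1.5-fold higher number from compound 2 to compound 4 (0.18 log units; within the scatter) and so shows no change beyond the scatter from the ring alone. The earlier step from compound 1 to compound 2 altered the ring and the drawing of the stereocentre together, so it did not isolate the ring. The pair with the same atoms and bonds shows a 3.6-fold higher number from compound 1 to compound 4 (0.56 log units; beyond the scatter) and differs in one respect only: the fact that one of compounds 1 and 4 is drawn with a defined configuration and the other without, at the place where they differ.

As far as these compounds go, what the samples drawn without a configuration actually contain stays open, and so does how the S form would behave. Also open, from the compounds shown here alone, is how an amine or a carboxylic acid would read on this saturated chain carbon.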